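The source may hold more compounds than are shown below. What is called first, only, known or untested is meant among the compounds shown, and "the series" means these compounds.

Measured so far:
compound 1 `CCCn1c(=O)n(C2OC(COP(=O)(O)O)[C@@H](O)[C@H]2O)c2nc(N)nc(O)c21`, 15 uM
compound 2 `Nc1nc(O)c2c(n1)n(C1OC(CO)[C@@H](O)[C@H]1O)c(=O)n2CC(O)CO`, 45 uM
compound 3 `C=CCn1c(=O)n([C@@H]2O[C@H](CO)[C@H]3OC(CCC)(CCC)O[C@H]32)c2nc(N)nc(O)c21`, 4 uM

All three numbers come from a functional assay (B cells) with Mus musculus as the target; on this read-out higher numbers stand for an effect only at larger amounts of compound and lower numbers for an effect already at smaller amounts. Compound 2 stands highest of the three: compound 1 sits at a lower number, beyond the scatter, and compound 3 lower still, also beyond the scatter. For the measured compounds named here, no step between measured compounds that differ in one place is available, so compound 4 is judged from the structural change alone. Compound 4 `CN(C)CCCn1c(=O)n(C2OC(CO)[C@@H](O)[C@H]2O)c2nc(N)nc(O)c21` differs from compound 2 by 2-(dimethylamino)ethyl in place of 1,2-dihydroxyethyl on a saturated chain carbon bound to an aromatic nitrogen. Compound 1 gives 15 uM, and compound 4 is expected to move in that direction. The expected step is a 3.0-fold lower number from compound 2 to compound 4 (0.48 log units; beyond the scatter), beyond the scatter. For compound 4 the estimate in this assay is 15 uM, within a range from 4 uM to 60 uM.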

Compound 4, concentration for half-maximal effect: 194 uM
Compound 4: the middle estimate sits 13-fold (1.11 log units) below what was measured; measured number above the stated range.
By their numbers in this assay, from the lowest: compound 3; then compound 1; then compound 2; then compound 4.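

In this assay, 2-(dimethylamino)ethyl in place of 1,2-dihydroxyethyl on a saturated chain carbon bound to an aromatic nitrogen gives a 4.3-fold higher number from compound 2 to compound 4 (0.63 log units; beyond the scatter) and so moves the read-out toward larger amounts of compound. For the compounds shown here, this is the first one-place step, and it shows that the read-out responds to the group at this position. Nothing available explains the direction of this step. As far as these compounds go, whether the step follows the loss of the hydroxyl groups or the arrival of the dimethylamino group stays open. A carboxylic acid or a longer alkyl chain at this position on the core of compound 2 would help separate the two.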